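A few compounds are considered here, and "the series" means these few. Any claim that something is new, unique, unknown or untested is made for them only; others in the source may bear on it.

In a functional assay on SK-N-SH cells (Homo sapiens) for inhibition, read by MTT assay, with a stated time of 72 h, tested at 30 uM (a lower number here means less inhibition of growth, a higher number more inhibition of growth at the concentration tested), compound 1 `C=CCc1cc(O)c(O)c(CN2CCC(CCO)CC2)c1` gives 15.3% and compound 2 `C=CCc1ccc(OCc2cn(-c3ccccc3Cl)nn2)c(O)c1` gives 10.2% at the single concentration tested. These two numbers lie within the usual scatter of each other, so compound 2 cannot be placed above or below compound 1. Compound 3 `C=CCc1ccc(OCc2cn(-c3cccc(C#N)c3)nn2)c(O)c1` carries 3-cyanophenyl in place of 2-chlorophenyl on an aromatic nitrogen and keeps the rest of compound 2 unchanged. Among the compounds with values here, no measured pair shows what such a swap does, so no change beyond the scatter is expected in this assay here. The estimated a number 1.8 percentage points higher from compound 2 to compound 3 (within the scatter) stays within that scatter. Compound 3 is expected at 12% with an estimated range from 2% to 25% for a measurement.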

Compound 3, percent growth inhibition at one concentration: 21.2%
For compound 3 the middle estimate is 9.2 percentage points below the measured one; measured number inside the range.
By their numbers in this assay, from the lowest: compounds 2, 1 and 3 (each within the scatter of the next, the first and the last beyond it).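

On an aromatic nitrogen of the five-membered ring, the choice of aryl group can shift growth inhibition: in this assay, 3-cyanophenyl in place of 2-chlorophenyl gives a number 11 percentage points higher from compound 2 to compound 3 (beyond the scatter). Within the data shown here, this is the first step in the set that can be read, and it is modest. The swap changes both the group on the phenyl ring and its place there, and nothing shown explains the step.

Which of those two changes matters remains open. So does how a plain phenyl, or a phenyl carrying an amine or a carboxylic acid, would compare.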